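The compounds below may be only part of what the source reports. "The series", "measured", "known", "first", "only" and "open" are said of these compounds alone.

Three compounds share one core and differ only in the group on one aromatic carbon. Compound 1 `Cc1cc(Br)c(S(C)(=O)=O)cc1C(=O)N=C(N)N` carries bromo there, and in a functional assay for inhibition of sodium/hydrogen exchanger (Oryctolagus cuniculus) (on this read-out higher numbers stand for weaker inhibition and lower numbers for stronger inhibition), compound 1 gives 12 nM. Compound 2 `Cc1cc(-c2ccco2)c(S(C)(=O)=O)cc1C(=O)N=C(N)N` carries furan-2-yl, and in this assay compound 2 gives 16 nM. Compound 3 `Cc1cc(Sc2ccccc2)c(S(C)(=O)=O)cc1C(=O)N=C(N)N` carries phenylsulfanyl, and in this assay compound 3 gives 14 nM. Compound 3 stands within the scatter of both of the others: the step from compound 1 to compound 3 is a 1.2-fold higher number from compound 1 to compound 3 (0.07 log units; within the scatter), the step from compound 2 to compound 3 is a 1.1-fold lower number from compound 2 to compound 3 (0.06 log units; within the scatter), and the step from compound 1 to compound 2 is a 1.3-fold higher number from compound 1 to compound 2 (0.12 log units; within the scatter).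

Compound 4 `Cc1cc(OC2CCCCC2)c(S(C)(=O)=O)cc1C(=O)N=C(N)N` has not yet been measured. It differs from compound 3 in one place: cyclohexyloxy in place of phenylsulfanyl on an aromatic carbon. The measured steps that bear on this change are the three exchanges at the same carbon, bromo to furan-2-yl, bromo to phenylsulfanyl and furan-2-yl to phenylsulfanyl, and none of them left the scatter. Since groups of quite different kinds at this carbon gave numbers within the scatter of one another, no step beyond the scatter is expected for compound 4 in this assay, that is a 1.1-fold higher number from compound 3 to compound 4 (0.03 log units; within the scatter). The estimate for compound 4 in this assay is 15 nM, with a range from 6 nM to 40 nM.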

Compound 4, half-maximal inhibitory concentration: 37 nM
Beside the measured number, compound 4's estimate is 2.5-fold (0.39 log units) below it; the measured number falls inside the stated range.
By their numbers in this assay, from the lowest: compounds 1, 3 and 2 (each within the scatter of the next); then compound 4.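

Among the compounds shown here, at this carbon, cyclohexyloxy gives the first steps beyond the scatter in this assay: (a 2.6-fold higher number from compound 3 to compound 4 (0.42 log units; beyond the scatter)) against phenylsulfanyl, (a 2.3-fold higher number from compound 2 to compound 4 (0.36 log units; beyond the scatter)) against furan-2-yl and (a 3.1-fold higher number from compound 1 to compound 4 (0.49 log units; beyond the scatter)) against bromo, all of them modest. The position therefore does not accept every group alike, even though the three earlier groups gave numbers within the scatter of one another. The closest comparison is with phenylsulfanyl, which has the same count of heavy atoms and hydrogen-bond acceptors and also a six-membered ring of carbon, so these matching counts did not keep the number within the scatter, and no measurement shown here explains the rise.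

The step from phenylsulfanyl to cyclohexyloxy changes both the linking atom, from sulfur to oxygen, and the ring, from aromatic to non-aromatic, so the compounds shown cannot assign the step to either change. Phenoxy and cyclohexylsulfanyl at this carbon would separate the two, while the compounds shown also leave open how an amine or a carboxylic acid would behave there.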